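This account rests on a few compounds, and the source may have more. Where it says the series, first, only, none or still open, it means among the compounds named here.

Measured in an ADME assay on HEp-2 cells (Homo sapiens) for cytotoxicity; on this read-out lower numbers stand for higher toxicity in this test and higher numbers for lower toxicity in this test:
- compound 1 `CC(C)CCn1c(Cn2c(=O)n(C(C)C)c3ccccc32)nc2cc(CN)ccc21`: 3920 nM
- compound 2 `CNCc1ccc2c(c1)nc(Cn1c(=O)n(C(C)C)c3ccccc31)n2CCC(C)C`: 1480 nM
- compound 3 `CC(C)CCn1c(Cn2c(=O)n(C(C)C)c3ccccc32)nc2cc(C(C)(C)N)ccc21`: 3270 nM

Compound 3 sits within the scatter of compound 1, as a 1.2-fold lower number from compound 1 to compound 3 (0.08 log units; within the scatter) shows, and clear of compound 2, as a 2.2-fold higher number from compound 2 to compound 3 (0.34 log units; beyond the scatter) shows. Compound 4 `CC(C)CCn1c(Cn2c(=O)n(C(C)C)c3ccccc32)nc2cc(CO)ccc21` carries hydroxymethyl in place of 1-amino-1-methylethyl on an aromatic carbon. The measured steps bear on this only loosely, since each swaps one nitrogen-bearing group for another. The largest, a 2.6-fold lower number from compound 1 to compound 2 (0.42 log units; beyond the scatter), is modest. Going by the values given here, no measured step shows hydroxymethyl replacing such a group, so in this assay a modest step is expected, tentatively upward. The estimated step is a 1.4-fold higher number from compound 3 to compound 4 (0.14 log units; within the scatter). For compound 4 the expected value is 4500 nM, within an estimated range of 1800 nM to 12000 nM.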

Compound 4, half-maximal cytotoxic concentration: 31600 nM
Compound 4: middle estimate off by 7.0-fold (0.85 log units), on the low side; measured number above the stated range.
By their numbers in this assay, from the lowest: compound 2; then compounds 3 and 1 (each within the scatter of the next); then compound 4.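

In this assay,  hydroxymethyl on this aromatic carbon gives a far higher number than any of the three amine-bearing groups: compared with 1-amino-1-methylethyl (a 9.7-fold higher number from compound 3 to compound 4 (0.99 log units; beyond the scatter)), with the methylamino chain (a 21-fold higher number from compound 2 to compound 4 (1.33 log units; beyond the scatter)) and with the amino chain (an 8.1-fold higher number from compound 1 to compound 4 (0.91 log units; beyond the scatter)). The earlier compounds shown here, which all carry a nitrogen here, stayed much closer together, so replacing that nitrogen with the oxygen of hydroxy moves the number more than any change among the amines did. Nothing given here explains the rise. Going by these compounds, whether a methoxymethyl group or a carboxylic acid at this place would also give a high number remains open.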